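The compounds below may be only part of what the source reports. "The series", "measured", "known", "first", "only" and "open" are said of these compounds alone.

Measured so far:
compound 1, `O=C(Nc1cccc(-n2cc(-c3ccncc3)c(-c3ccc(Cl)c(O)c3)n2)c1)Nc1cccc(C(F)(F)F)c1`: > 32500 nM
compound 2, `COc1cc(-c2nn(-c3cccc(NC(=O)c4cccc(C(F)(F)F)c4)c3)cc2-c2ccncc2)ccc1Cl`: 2780 nM

Among the compounds with values here, in a functional assay on A498 cells (Homo sapiens) for inhibition, read by sulforhodamine B assay, with a stated time of 48 h (a lower number here means a stronger inhibitor of growth, a higher number a weaker inhibitor of growth), compound 2 gives 2780 nM, the only plain number among the two results. For compound 1 the result > 32500 nM is a limit of the assay rather than a number (the limit of > 32500 nM in this assay, at which 1 of the 2 values shown sits). Compound 3, `COc1cc(-c2nn(-c3cccc(NC(=O)c4ccc(Cl)c(C(F)(F)F)c4)c3)cc2-c2ccncc2)ccc1Cl`, has not yet been measured. It differs from compound 2 by chloro in place of hydrogen on an aromatic carbon. Within the data shown here, no step between measured compounds is available to guide the size of this change. The step from compound 2 to compound 3 is expected to be a small gain, about a 1.9-fold lower number from compound 2 to compound 3 (0.27 log units; within the scatter), close to the usual scatter. Compound 3 is therefore estimated at 1500 nM, between 500 nM and 5000 nM.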

Compound 3, concentration for total growth inhibition: 22700 nM
Beside the measured number, compound 3's estimate is 15-fold (1.18 log units) below it; the whole stated range lies below it.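

In this assay, adding one chloro to the 3-(trifluoromethyl)phenyl ring gives an 8.2-fold higher number from compound 2 to compound 3 (0.91 log units; beyond the scatter), the only step shown at this position. This shows that the position is not indifferent to change: a single added chlorine atom, ortho to the trifluoromethyl group, weakens growth inhibition beyond the usual scatter. Nothing shown here explains why this one atom has such an effect. Going by these compounds, whether a fluoro or an amino group on the same carbon would bring a similar loss remains open. So does whether the loss depends on the neighbouring trifluoromethyl group being present.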